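Replacing Methylsulfanyl with Propoxy: A Cytotoxicity Expectation

This account rests on a few compounds, and the source may have more. Where it says the series, first, only, none or still open, it means among the compounds named here.

Measured in a functional assay on HT-29 cells (Homo sapiens) for cytotoxicity; a lower number here means that less compound is needed, a higher number that more compound is needed for the effect:
- Compound 1 `COc1ccc(/C=C/c2cc(OC)c(OC(C)=O)c(OC)c2)cc1`: 11.7 uM
- Compound 2 `COc1cc(/C=C/c2ccc(SC)cc2)cc(OC)c1OC`: 8.3 uM

The account starts from compound 2, which gives 8.3 uM in this assay. Compound 1 gives 11.7 uM, and these two values lie within the usual scatter of each other, so the numbers set neither compound ahead of the other.

The next compound is compound 3 `CCCOc1ccc(/C=C/c2cc(OC)c(OC)c(OC)c2)cc1`. In it, propoxy stands in place of methylsulfanyl on an aromatic carbon of a six-membered aromatic ring of carbon only, para to a large group (propoxy in place of methylsulfanyl on an aromatic carbon). The two measured compounds differ in more than one place, so the data hold no direct measure of this exchange.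

Among the measured compounds shown here, the only guide is the closeness of the two measured values, so a small move towards a higher number is expected, about the size of the scatter. The estimated step is a 1.7-fold higher number from compound 2 to compound 3 (0.23 log units; within the scatter). For compound 3 the estimated value is 14 uM, with an expected range from 5 uM to 40 uM.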

Compound 3, concentration for half-maximal effect: > 25 uM
Compound 3: a limit, no number; the forecaster's own chance of this, stated with the estimate: 10%; middle value at least 1.7-fold (0.25 log units) away from the limit.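

In this assay compound 3 gives > 25 uM, which is a limit of the assay and not a number. Propoxy in place of methylsulfanyl on this aromatic carbon gives an at least 3.0-fold higher number from compound 2 to compound 3 (0.47 log units; beyond the scatter), so the position does not accept this exchange without a change in the read-out, something compound 1 and compound 2 could not show because they differ in more than one place. This step marks only the smallest size the change can have, and its full size stays unknown because the value of compound 3 is a limit: the limit of > 25 uM in this assay, at which 1 of the 3 values shown sits.

The compounds shown leave open how far compound 3 lies beyond its limit, and whether the loss follows the exchange of sulfur for oxygen, the longer chain or both, since the two groups differ in both respects. Propylsulfanyl or ethoxy on the same carbon would pull these two apart, while an amine there would show whether this position can carry a group of a different kind at all.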